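The compounds below may be only part of what the source reports. "The series", "measured", "known", "first", "only" and "open" are said of these compounds alone.

Measured so far:
Compound 1, `CC(c1cc(F)c2ncccc2c1)n1cnc2ncc(-c3ccncc3)nc21`: in a functional assay on NCI-H1993 cells (Homo sapiens) for inhibition, read by CCK-8 assay, with a stated time of 72 h (on this read-out higher numbers stand for weaker inhibition and lower numbers for stronger inhibition), compound 1 gives > 10000 nM, which is a limit of the assay and not a number.
Compound 2, `CC(c1cc(F)c2ncccc2c1)n1cnc2ncc(-c3ccccc3)nc21`: in this assay compound 2 gives > 10000 nM, again a limit and not a number.
Compound 3, `c1cnc2ccc(Cn3cnc4ncc(-c5ccncc5)nc43)cc2c1`: in this assay compound 3 gives 1160 nM.

Within the data shown here, compound 3 is the only compound with a number here; the other two values sit at a limit (the limit of > 10000 nM in this assay, at which 2 of the 3 values shown sit). The change from compound 1 to compound 2, (phenyl in place of pyridin-4-yl on an aromatic carbon), gives a step that the two limits leave unreadable from compound 1 to compound 2, so its size is not readable. The difference between the core of compound 1 and the core of compound 3 is not broken down here.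

Compound 4, `c1ccc(-c2cnc3ncn(Cc4ccc5ncccc5c4)c3n2)cc1`, carries the same change on the core of compound 3: phenyl in place of pyridin-4-yl on an aromatic carbon. The place is the same word for word, so this is the same change. Among the measured compounds shown here, its one measured instance is unreadable, so nothing here sizes it; the step from compound 3 to compound 4 is expected to be a 1.3-fold higher number from compound 3 to compound 4 (0.11 log units; within the scatter), that is, small. Compound 4 is estimated at 1500 nM, expected between 500 nM and 5000 nM.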

Compound 4, half-maximal inhibitory concentration: 7490 nM
Compound 4: middle estimate off by 5.0-fold (0.70 log units), on the low side; the whole stated range lies below it.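

On the core of compound 3, phenyl in place of pyridin-4-yl gives a 6.5-fold higher number from compound 3 to compound 4 (0.81 log units; beyond the scatter) in this assay, which is weaker inhibition on this one core. Among these compounds, this is the only readable instance of the change, so it shows neither that the step carries over to another core nor that its size would hold there. On the core of compound 1 the same change cannot be read, as the values of compound 1 and compound 2 are limits and not numbers: the limit of > 10000 nM in this assay, at which 2 of the 4 values shown sit.

Still open, from the compounds shown here alone, is how other groups on this aromatic carbon, such as pyridin-3-yl, an amine or a carboxylic acid, would read on either core. Also open, going by these compounds, is which part of the difference between the core of compound 1 and the core of compound 3 goes with the gap in their values.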